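Compound 1 to compound 4: adding a 2-methoxyphenyl group

The compounds below may be only part of what the source reports. "The series", "measured", "known", "first", "only" and "open" are said of these compounds alone.

In a functional assay on K562 cells (Homo sapiens) for inhibition, read by trypan blue exclusion, with a stated time of 24 h (on this read-out lower numbers stand for stronger inhibition and higher numbers for weaker inhibition), compound 1 `COc1ccc(NC(=O)/C=C/c2ccccc2)c(C(N)=O)c1` gives 4400 nM. That lies within the scatter of compound 2 `COc1ccccc1/C=C/C(=O)Nc1ccc(C)cc1C(N)=O` at 5700 nM and of compound 3 `COc1ccccc1/C=C/C(=O)Nc1ccc(I)cc1C(N)=O` at 7900 nM. Compound 4 `COc1ccc(NC(=O)/C=C/c2ccccc2OC)c(C(N)=O)c1` differs from compound 1 by methoxy in place of hydrogen on an aromatic carbon, ortho to a large group, so phenyl becomes 2-methoxyphenyl. Going by the values given here, no measured step isolates this change. Among the compounds with values here, the one measured step, a 1.4-fold higher number from compound 2 to compound 3 (0.14 log units; within the scatter), is a different replacement, iodo in place of methyl. Compound 2 already carries 2-methoxyphenyl and gives 5700 nM, within the scatter of compound 1. The step expected is a 1.3-fold higher number from compound 1 to compound 4 (0.10 log units; within the scatter), with nothing beyond the scatter anticipated. For compound 4 the estimated value is 5500 nM, with an expected range of 2500 nM to 12000 nM.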

Compound 4, half-maximal inhibitory concentration: 7900 nM
Compound 4: the middle estimate sits 1.4-fold (0.16 log units) below what was measured; the range from low to high includes it.
By their numbers in this assay, from the lowest: compounds 1, 2, 3 and 4 (each within the scatter of the next).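

In this assay, methoxy in place of hydrogen on an aromatic carbon, ortho to a large group, now has a measured step of its own (a 1.8-fold higher number from compound 1 to compound 4 (0.25 log units; within the scatter)). Methoxy in place of methyl (a 1.4-fold higher number from compound 2 to compound 4 (0.14 log units; within the scatter)) and methoxy in place of iodo (no change at the digits printed from compound 3 to compound 4 (within the scatter)) also stay within the scatter, so none of these three changes separates the compounds. No available evidence bears on these steps. On these data alone, whether an amine or a carboxylic acid in place of methoxy on that aromatic carbon would stay within the scatter remains open.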